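Pyrimidin-2-yl in place of phenyl on the benzyl ether

This account rests on a few compounds, and the source may have more. Where it says the series, first, only, none or still open, it means among the compounds named here.

In an ADME assay (liver) for pharmacokinetics, with Liver microsome (Rattus norvegicus) as the target, read by LC-MS, using microsomes, tested at 2 uM (a lower number here means slower removal, a higher number faster removal of the compound), compound 1 `O=C(N[C@@H]1CCCC[C@H]1O)c1cnc(OC2CCC2)c(-c2ccc(Cl)cc2)c1` gives 0.21 mL/min/kg and compound 2 `O=C(N[C@@H]1CCCC[C@H]1O)c1cnc(OCc2ccccc2)c(-c2ccc(Cl)cc2)c1` gives 0.02 mL/min/kg, the lower of the two numbers. Compound 3 `O=C(N[C@@H]1CCCC[C@H]1O)c1cnc(OCc2ncccn2)c(-c2ccc(Cl)cc2)c1` carries pyrimidin-2-yl in place of phenyl on a saturated chain carbon bound to an oxygen on an aromatic ring. Among the compounds with values here, the only measured step, an 11-fold lower number from compound 1 to compound 2 (1.02 log units; beyond the scatter), is large and beyond the scatter, but it exchanged cyclobutyl for benzyl and does not test this ring exchange. Direction is therefore uncertain, and a small rise in this assay is expected, giving an expected 2.0-fold higher number from compound 2 to compound 3 (0.30 log units; within the scatter). For compound 3 the estimated value is 0.04 mL/min/kg, with a range of 0.01 mL/min/kg to 0.2 mL/min/kg.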

Compound 3, clearance: 0.012 mL/min/kg
For compound 3 the middle estimate is 3.3-fold (0.52 log units) above the measured one, and the stated range covers the measured number.
By their numbers in this assay, from the lowest: compounds 3 and 2 (each within the scatter of the next); then compound 1.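

In this assay the ring exchange gives a 1.7-fold lower number from compound 2 to compound 3 (0.22 log units; within the scatter) and so leaves the number unmoved within the scatter, although the entering pyrimidin-2-yl brings ring nitrogen in place of carbon. The large gap to the cyclobutyl ether survives this exchange, with an 18-fold lower number from compound 1 to compound 3 (1.24 log units; beyond the scatter) as the step beyond the scatter. No supporting measurement bears on why the position accepts both rings.

Still open, from the compounds shown here alone, is whether an amine or carboxylic acid on the ring, or a longer chain between the oxygen and the ring, would hold the number this low.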